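Methylphenyl in Place of a Halogenated Ring on the Anilino Nitrogen

The compounds below may be only part of what the source reports. "The series", "measured", "known", "first", "only" and "open" are said of these compounds alone.

Of the compounds shown here, three built on one shared core have been measured in a functional assay on NCI-H1975 cells (Homo sapiens) for antiproliferative activity, read by MTT assay, with a stated time of 72 h; on this read-out higher numbers stand for weaker inhibition and lower numbers for stronger inhibition. Compound 2 `COc1cc2ncnc(Nc3ccc(Cl)c(C(F)(F)F)c3)c2cc1OCCCCC(=O)Nc1ccc(S(N)(=O)=O)cc1` gives 3220 nM, the lowest number of the three. Compound 1 `COc1cc2ncnc(Nc3ccc(F)c(Cl)c3)c2cc1OCCCCC(=O)Nc1ccc(S(N)(=O)=O)cc1` gives 35600 nM, and compound 3 `COc1cc2ncnc(Nc3cccc(C)c3)c2cc1OCCCCC(=O)Nc1ccc(S(N)(=O)=O)cc1` gives 32100 nM. The steps between them read as follows: an 11-fold lower number from compound 1 to compound 2 (1.04 log units; beyond the scatter); a 10-fold higher number from compound 2 to compound 3 (1.00 log units; beyond the scatter); and a 1.1-fold lower number from compound 1 to compound 3 (0.04 log units; within the scatter). Compound 2 therefore stands clearly apart, while compound 1 and compound 3 sit within the scatter of each other.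

Compound 4 `COc1cc2ncnc(Nc3ccc(C)cc3)c2cc1OCCCCC(=O)Nc1ccc(S(N)(=O)=O)cc1` differs from compound 2 in one place: 4-methylphenyl in place of 4-chloro-3-(trifluoromethyl)phenyl on a nitrogen on an aromatic ring. The measured step that bears most directly on this change is a 10-fold higher number from compound 2 to compound 3 (1.00 log units; beyond the scatter), where a methylphenyl likewise took the place of the 4-chloro-3-(trifluoromethyl)phenyl and the number rose by a modest but clear margin. Compound 1 gives no direct comparison for a methylphenyl, but its own value of 35600 nM shows that another halogenated ring also sits well above compound 2. A step upward of about the same size as that seen for compound 3 is expected here. For compound 4 the expected step is a 9.3-fold higher number from compound 2 to compound 4 (0.97 log units; beyond the scatter). Compound 4 is estimated at 30000 nM, within a range from 10000 nM to 90000 nM.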

Compound 4, half-maximal inhibitory concentration: 19300 nM
Compound 4: middle estimate off by 1.6-fold (0.19 log units), on the high side; the measured number falls inside the stated range.
By their numbers in this assay, from the lowest: compound 2; then compounds 4, 3 and 1 (each within the scatter of the next).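

The change to 4-methylphenyl brings a 6.0-fold higher number from compound 2 to compound 4 (0.78 log units; beyond the scatter) and this shows that the rise seen with 3-methylphenyl is not tied to that one ring. The place of the methyl group on the ring makes no clear difference in this set: the two methylphenyl compounds are separated only by a 1.7-fold lower number from compound 3 to compound 4 (0.22 log units; within the scatter) and that gap gives them no order. The 3-chloro-4-fluorophenyl ring also cannot be told apart from 4-methylphenyl, with a 1.8-fold lower number from compound 1 to compound 4 (0.27 log units; within the scatter) so among these four compounds only the 4-chloro-3-(trifluoromethyl)phenyl ring stands apart, and compound 1 shows that carrying halogens is not enough on its own.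

Nothing shown here explains why compound 2 stands apart. The compounds shown also leave open whether its lower number needs both substituents or just one, which 4-chlorophenyl and 3-(trifluoromethyl)phenyl rings on the same nitrogen could separate, and whether a ring bearing an amine or a carboxylic acid would behave like the methylphenyl rings or like compound 2.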